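The source may hold more compounds than are shown below. What is called first, only, known or untested is meant among the compounds shown, and "the series" means these compounds.

Measured compounds:

Compound 1, `N#CC1=C(N)Oc2c(c3nc4ccccc4nc3c3ccccc23)C12C(=O)N(Cc1cnnn1-c1ccc([N+](=O)[O-])cc1)c1ccccc12`, in a functional assay on A549 cells (Homo sapiens) for antiproliferative activity, read by MTT assay, with a stated time of 48 h (a higher number here means a weaker inhibitor, a lower number a stronger inhibitor), gives only a limit, > 50000 nM.
Compound 2, `N#CC1=C(N)Oc2c(c3nc4ccccc4nc3c3ccccc23)C12C(=O)N(Cc1cnnn1-c1ccc(S(N)(=O)=O)cc1)c1ccccc12`, in this assay likewise gives only a limit, > 50000 nM.
Compound 3, `N#CC1=C(N)Oc2c(N)cc3nc4ccccc4nc3c2C12C(=O)N(Cc1cnnn1-c1cccc(Br)c1)c1ccccc12`, in this assay gives 18900 nM.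

Among the compounds with values here, compound 3 is the one compound of the three with an actual number; the other two sit at the limit of > 50000 nM in this assay, at which 2 of the 3 values shown sit, so compound 3 stands alone as the sole readable point in the set. Within the data shown here, the one step between measured compounds, a step that the two limits leave unreadable from compound 1 to compound 2, runs between two limits and gives no readable size, so it says nothing about the change considered here.

Compound 4, `Cc1cc(C)c(-n2nncc2CN2C(=O)C3(C(C#N)=C(N)Oc4c(N)cc5nc6ccccc6nc5c43)c3ccccc32)c(C)c1`, differs from compound 3 in one place: 2,4,6-trimethylphenyl in place of 3-bromophenyl on an aromatic nitrogen. Among the measured compounds shown here, no measured step touches this position, and the one step that exists is unreadable, so there is nothing to carry over. With no evidence for a shift in either direction, the expectation for compound 4 is a value within the scatter of compound 3, that is, a step of about a 1.1-fold higher number from compound 3 to compound 4 (0.02 log units; within the scatter). Compound 4 is therefore estimated at 20000 nM in this assay, with a range from 7000 nM to 60000 nM.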

Compound 4, half-maximal inhibitory concentration: 12700 nM
Estimate against measurement, compound 4: 1.6-fold (0.20 log units) above; measured number inside the range.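

In this assay, within the data shown here, the swap of 3-bromophenyl for 2,4,6-trimethylphenyl on the aromatic nitrogen of the five-membered ring gives the one readable step: a 1.5-fold lower number from compound 3 to compound 4 (0.17 log units; within the scatter). The earlier compounds shown here gave no size for any change on this aryl group; this step shows that, on the core shared by compound 3 and compound 4, an aryl group carrying bromine and one carrying methyl groups cannot be told apart within the scatter. Nothing measured here bears on why these two groups read alike.

Going by these compounds, the earlier step, sulfamoyl in place of nitro on the core of compound 1, runs between two limits and cannot be read, so the effect of a substituent on that core remains unknown. Also open, on these data alone, is whether a phenyl group carrying an amine or a carboxylic acid, or a longer alkyl chain in place of the aryl group on this nitrogen, would separate from compound 3 by more than the scatter.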